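Adding a Carboxy Group to a Weakly Cytotoxic Amide

The source may report more compounds than this note shows. Statements on the series, on what has been measured and on what is new or still open speak of the compounds shown alone.

Measured compounds:
Compound 1, `Cc1ccc(-c2nc3ccccc3s2)cc1NC(=O)c1cc([N+](=O)[O-])c(N2CCCCC2)cc1Cl`, in an ADME assay on Raji cells (Homo sapiens) for cytotoxicity, with a stated time of 72 h; on this read-out lower numbers stand for an effect already at smaller amounts and higher numbers for an effect only at larger amounts of compound: > 25000 nM.
Compound 2, `O=C(Nc1nc(-c2cccc(F)c2)cs1)c1cc([N+](=O)[O-])ccc1Cl`, in this assay: 11000 nM.

For compound 1 the value of > 25000 nM is a limit of this assay, not a measured number. It thus stands at the limit of > 25000 nM in this assay, at which 1 of the 2 values shown sits. Among the compounds with values here, compound 2 is the only compound here with a number, 11000 nM in this assay; compound 1 and compound 2 differ in many places at once, so their two values say nothing about any single change.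

The unmeasured compound 3, `Cc1ccc(-c2nc3ccccc3s2)cc1NC(=O)c1cc([N+](=O)[O-])c(N2CCC(C(=O)O)CC2)cc1Cl`, differs from compound 1 in one place: carboxy in place of hydrogen on a saturated ring carbon. Nothing measured here speaks to that change, so the expected step that the limit leaves unreadable from compound 1 to compound 3 is none beyond the scatter. Compound 3 is therefore estimated at 30000 nM, with a range from 10000 nM to 100000 nM, and it will most likely again be reported only as a limit.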

Compound 3, half-maximal effective concentration: > 25000 nM
Compound 3 gave a limit, no number; the forecaster's own chance of this, stated with the estimate: 80%; the middle value lies beyond the limit too.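

Compound 1 and compound 3 both give only a limit in this assay, not a number, and no step can be read between them. The compounds shown leave open whether carboxy in place of hydrogen on a saturated ring carbon changes the cytotoxicity at all.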